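The source may hold more compounds than are shown below. What is called first, only, known or untested is meant among the compounds shown, and "the series" means these compounds.

Compound 1, `CCS(=O)(=O)CCC12CCC(c3nnc(-c4ccccc4Br)n3C)(CC1)CC2`: 65%
Compound 2, `Cn1c(-c2ccccc2C(F)(F)F)nnc1C12CCC(CCCC(C)(F)F)(CC1)CC2`: 94%
Compound 3, `CC(C)S(=O)(=O)CCC12CCC(c3nnc(-c4ccccc4C(F)(F)F)n3C)(CC1)CC2`: 59%

In a functional assay on the whole organism (strain ICR) for inhibition, with Mus musculus as the target, with a stated time of 16 h, at a dose of 10 mg/kg by the oral route (on this read-out higher numbers stand for more inhibition at the one dose given (going by the name of the read-out) and lower numbers for less inhibition), compound 3 gives 59%, the lowest of the three numbers shown. Compound 1 lies nearest to it, with a value within the usual scatter, while compound 2 stands well beyond it. Compound 4, `CC(F)CCCC12CCC(c3nnc(-c4ccccc4C(F)(F)F)n3C)(CC1)CC2`, differs from compound 3 in one place: 2-fluoropropyl in place of isopropylsulfonyl on a saturated chain carbon, two bonds along the chain from a saturated ring carbon.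

Among the compounds with values here, one measured step bears on this change. Compound 2 and compound 3 differ at the same chain carbon, and the sulfonyl group brought a large drop: a number 35 percentage points lower from compound 2 to compound 3 (beyond the scatter). The change to compound 4 runs the other way in kind, a sulfonyl group leaving and a fluorine-bearing chain entering, so a rise beyond the scatter is expected, though the entering group is not the same as that of compound 2. The step is estimated at a number 26 percentage points higher from compound 3 to compound 4 (beyond the scatter), and compound 4 is expected to give 85% in this assay, with a range from 65% to 98%.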

Compound 4, a percentage reported as inhibition, in the whole organism at one dose (the size of the read-out at that dose, not a potency): 51%
The estimate for compound 4 lay 34 percentage points above the measured number, outside the stated range (below it).
By their numbers in this assay, from the lowest: compounds 4, 3 and 1 (each within the scatter of the next, the first and the last beyond it); then compound 2.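

In this assay, taking away the sulfonyl group did not by itself restore the high number: the step reads a number 8 percentage points lower from compound 3 to compound 4 (within the scatter), so at this place on the chain the isopropylsulfonyl and 2-fluoropropyl groups are not told apart. The large step lies instead at the fluorine-bearing chain carbon, where hydrogen in place of fluoro gives a number 43 percentage points lower from compound 2 to compound 4 (beyond the scatter), so the number at this position depends on more than the loss of the sulfonyl group. No measurement shown gives a reason for either step.

Left open is how a chain with no fluorine, or an amine or a carboxylic acid at this place, would read in this assay. Also open, as far as these compounds go, is whether the large step at the fluorine-bearing carbon would recur on a longer chain.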